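This account rests on a few compounds, and the source may have more. Where it says the series, first, only, none or still open, it means among the compounds named here.

In a functional assay on 1321N1 cells for antagonist activity at P2Y purinoceptor 6 (Homo sapiens), read by fluorescence and calcium flux (on this read-out lower numbers stand for stronger inhibition and higher numbers for weaker inhibition), compound 1 `O=C(O)C1=Cc2cc(I)ccc2OC1C(F)(F)F` reaches only the limit of the assay, reported as > 100000 nM rather than as a number. Compound 2 `COC(=O)[C@H](C)NC(=O)c1ccc(C#Cc2ccc3c(c2)C=C([N+](=O)[O-])C(C(F)(F)F)O3)cc1` gives 6840 nM and compound 3 `O=C(O)CCCC(=O)NCC#Cc1ccc2c(c1)C=C([N+](=O)[O-])C(C(F)(F)F)O2` gives 69100 nM; of the two numbers measured, compound 2 stands lowest, with compound 3 clearly above it. Compound 4 `COC(=O)c1ccc(C#Cc2ccc3c(c2)C=C([N+](=O)[O-])C(C(F)(F)F)O3)cc1` has not yet been measured in this assay. It differs from compound 2 in one place: methoxy in place of (1-(methoxycarbonyl)ethyl)amino on a carbonyl carbon. No measured pair among these compounds shows what this kind of change does in this assay. Compound 4 is expected to give a higher number than compound 2, that is weaker inhibition, with the expected step of a 2.2-fold higher number from compound 2 to compound 4 (0.34 log units; beyond the scatter). The estimate for compound 4 is 15000 nM, with a likely range from 4000 nM to 60000 nM.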

Compound 4, half-maximal inhibitory concentration: 7130 nM
Compound 4: middle estimate off by 2.1-fold (0.32 log units), on the high side, and the stated range covers the measured number.
By their numbers in this assay, from the lowest: compounds 2 and 4 (each within the scatter of the next); then compound 3. At a limit, above all of these: compound 1.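

Going by these compounds alone, replacing (1-(methoxycarbonyl)ethyl)amino with methoxy on this carbonyl carbon gives a 1.0-fold higher number from compound 2 to compound 4 (0.02 log units; within the scatter), the first measured pair for this change. At this position, the larger group, with its hydrogen-bond donor and defined stereocentre, can therefore give way to methoxy with no difference beyond the usual scatter. Nothing measured here accounts for this result.

This single pair leaves open whether other groups on this carbonyl carbon, such as an unsubstituted amide or an ester with a longer chain, would also leave the number unchanged.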